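This account rests on a few compounds, and the source may have more. Where it says the series, first, only, none or still open, it means among the compounds named here.

Of the compounds shown here, three with a shared core have been measured in a functional assay on NCI-H226 cells (Homo sapiens) for inhibition, read by sulforhodamine B assay, with a stated time of 48 h; on this read-out higher numbers stand for weaker inhibition of growth and lower numbers for stronger inhibition of growth. Compound 1 `COc1cc(-c2nn(-c3cccc(NC(=O)Nc4cc(C(F)(F)F)cc(C(F)(F)F)c4)c3)cc2-c2ccncc2)ccc1Cl` gives 1360 nM in this assay; compound 2 `COc1cc(-c2nn(-c3cccc(NC(=O)Nc4ccc(Cl)c(Cl)c4)c3)cc2-c2ccncc2)ccc1Cl` gives 1350 nM; compound 3 `O=C(Nc1cccc(-n2cc(-c3ccncc3)c(-c3ccc(Cl)c(O)c3)n2)c1)Nc1ccc(Cl)c(Cl)c1` gives 1510 nM. Among the compounds with values here, the number for compound 2 is not separated from either of the other two beyond the scatter, and the one single-point step available, a 1.1-fold higher number from compound 2 to compound 3 (0.05 log units; within the scatter), also lies within it, so the three values describe a single level rather than a spread. Within the data shown here, compound 1 and compound 2 differ in more than one place, and no step is computed between them; their two numbers simply sit together.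

Compound 4 `COc1cc(-c2nn(-c3cccc(NC(=O)c4ccc(Cl)c(C(F)(F)F)c4)c3)cc2-c2ccncc2)ccc1Cl` has not yet been measured. It differs from compound 2 by 4-chloro-3-(trifluoromethyl)phenyl in place of (3,4-dichlorophenyl)amino on a carbonyl carbon. Among the measured compounds shown here, none of the measured steps bears on this change: the step from compound 2 to compound 3 concerns the oxygen on the aromatic ring, not the carbonyl carbon. There is therefore no measured basis for a direction, and the expected step of a 1.0-fold higher number from compound 2 to compound 4 (0.02 log units; within the scatter) is taken as no change beyond the scatter, with a widened range to reflect the absence of precedent. Compound 4 is estimated at 1400 nM, between 500 nM and 4000 nM.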

Compound 4, concentration for 50% growth inhibition: 5900 nM
Compound 4: middle estimate off by 4.2-fold (0.62 log units), on the low side, and the stated range ends below it.
By their numbers in this assay, from the lowest: compounds 2, 1 and 3 (each within the scatter of the next); then compound 4.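

In this assay the change on the carbonyl carbon gives a 4.4-fold higher number from compound 2 to compound 4 (0.64 log units; beyond the scatter) and so weaker inhibition of growth, the first step among these compounds to lie beyond the scatter. Within the data shown here, the number therefore responds to what sits on this carbonyl carbon, whereas the one earlier step, at the oxygen on the aromatic ring, stayed within the scatter. Nothing given here explains the step.

The change swaps the amino link, with its hydrogen-bond donor, and also replaces a chlorine on the aromatic ring with trifluoromethyl, so the compounds shown do not separate these two parts of the step. They also leave open how a 3,4-dichlorophenyl group attached directly to the carbonyl carbon, a (4-chloro-3-(trifluoromethyl)phenyl)amino group or a saturated amine such as piperidine would read at this position.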